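The compounds below may be only part of what the source reports. "The series", "measured", "known", "first", "only" and "open" are said of these compounds alone.

Among the measured compounds shown here, compound 2 `CCCc1ccc(NC(=O)N[C@@H](C)c2ccccc2)cc1` stands lowest of the two numbers so far: in an ADME assay on the whole organism with Oryza sativa as the target, tested at 1 uM (on this read-out lower numbers stand for a stronger effect and higher numbers for a weaker effect at the one concentration tested), compound 2 gives 76%, whereas compound 1 `CC(C)c1ccc(NC(=O)N[C@@H](C)c2ccccc2)cc1` gives 96%. For the measured compounds named here, the one measured step, a number 20 percentage points lower from compound 1 to compound 2 (beyond the scatter), is the only change of the chain on the aromatic carbon yet seen. Compound 3 `CCCCc1ccc(NC(=O)N[C@@H](C)c2ccccc2)cc1` differs from compound 2 by methyl in place of hydrogen on a saturated chain carbon, three bonds along the chain from an aromatic carbon. That earlier step bears on this one only loosely, as the chain is lengthened rather than rearranged. From compound 2 the expected step is a number 6 percentage points lower from compound 2 to compound 3 (within the scatter), a small further fall or nothing beyond the scatter. For compound 3 the estimate is 70%, within 55% to 90%.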

Compound 3, a percentage reported as activity, at one concentration (the size of the read-out at that concentration, not a potency): 72%
Compound 3: middle estimate off by 2 percentage points, on the low side; the range from low to high includes it.
By their numbers in this assay, from the lowest: compounds 3 and 2 (each within the scatter of the next); then compound 1.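

In this assay, methyl in place of hydrogen on a saturated chain carbon, three bonds along the chain from an aromatic carbon, gives a number 4 percentage points lower from compound 2 to compound 3 (within the scatter), so propyl and butyl cannot be told apart here. Replacing the branched chain with the longer straight one gives a number 24 percentage points lower from compound 1 to compound 3 (beyond the scatter), which leaves compound 2 and compound 3 together and compound 1 apart from both. No evidence on the origin of these steps is at hand. On these data alone, whether a longer chain such as hexyl stays level with butyl remains open, as does the outcome for a chain ending in an amine or a carboxylic acid.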